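A few compounds are considered here, and "the series" means these few. Any claim that something is new, unique, unknown or untested is made for them only; others in the source may bear on it.

In an ADME assay on HEK293 cells (Homo sapiens) for cytotoxicity, with a stated time of 72 h (on this read-out higher numbers stand for an effect only at larger amounts of compound and lower numbers for an effect already at smaller amounts), three compounds on a shared core have been measured. Compound 1 `COc1ccc(/C=C/[C@@](C)(/C=C/c2ccc(O)c(C=O)c2)CCC=C(C)C)cc1` carries a formyl group and gives 2270 nM in this test. Compound 3 `COc1ccc(/C=C/[C@@](C)(/C=C/c2ccc(O)c(/C=C/C(C)=O)c2)CCC=C(C)C)cc1` has 2-acetylethenyl in that place and gives 14600 nM as the higher of the two exact numbers. Compound 2 `CCOC(=O)/C=C/c1cc(/C=C/[C@](C)(/C=C/c2ccc(OC)cc2)CCC=C(C)C)ccc1O` gives > 36600 nM as a limit and not an exact number.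

Compound 4 `COc1ccc(/C=C/[C@@](C)(/C=C/c2ccc(O)cc2)CCC=C(C)C)cc1` loses the side group altogether: hydrogen in place of 2-acetylethenyl on an aromatic carbon in the change from compound 3, which puts hydrogen in place of 2-acetylethenyl on an aromatic carbon. Going by the values given here, no measured step makes exactly this change. The closest evidence comes from swaps on the same carbon, which gave a 6.4-fold higher number from compound 1 to compound 3 (0.81 log units; beyond the scatter) and also an at least 16-fold higher number from compound 1 to compound 2 (1.20 log units; beyond the scatter) in the two cases starting from formyl. Exchanging one longer group for the other gave an at least 2.5-fold lower number from compound 2 to compound 3 (0.39 log units; beyond the scatter) as a smaller shift. Only compound 1 has a low number, and compound 4 has no formyl group, just as compound 3 has none. The expected result is therefore a 1.2-fold lower number from compound 3 to compound 4 (0.09 log units; within the scatter) with no shift beyond the scatter, though the uncertainty is wide. For compound 4 the estimated value is 12000 nM within an expected range of 4000 nM to 36000 nM in this test.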

Compound 4, half-maximal effective concentration: > 36600 nM
Compound 4 ended at the assay's limit; the forecaster's own chance of this, stated with the estimate: 20%; at least 3.0-fold (0.48 log units) between middle value and limit.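

In this assay, the position now has a baseline with nothing on it: taking away the side group gives an at least 2.5-fold higher number from compound 3 to compound 4 (0.39 log units; beyond the scatter), so 2-acetylethenyl, on this aromatic carbon ortho to a hydroxy group, goes with an effect at smaller amounts of compound than hydrogen does. Formyl goes further, with an at least 16-fold higher number from compound 1 to compound 4 (1.20 log units; beyond the scatter) when hydrogen takes its place, so the low number of compound 1 is tied to a group present at this carbon and not merely to the absence of a longer one. Compound 4 stands at a limit and not at an exact number, and its step from compound 2, also a limit, cannot be read: the limit of > 36600 nM in this assay, at which 2 of the 4 values shown sit.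

As far as these compounds go, how far compound 4 lies past that limit is unknown, so the true size of both readable steps stays open, as does whether 2-(ethoxycarbonyl)ethenyl differs from hydrogen at all. The compounds shown also do not tell whether a hydroxymethyl group, an amine or a carboxylic acid on this carbon would bring the number as low as formyl does.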